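The source may hold more compounds than are shown below. What is called first, only, known or untested is meant among the compounds shown, and "the series" means these compounds.

Measured so far:
Compound 1, `O=C(Nc1cccc(-c2ccc(F)cc2)c1)C(Cl)Cl`: 26200 nM
Compound 2, `O=C(Nc1cccc(-c2ccsc2)c1)C(Cl)Cl`: > 50000 nM

Two compounds share the same core, a dichloroacetamide on a benzene ring that carries a second aromatic ring. In a functional assay on KB 3-1 cells (Homo sapiens) for cytotoxicity, read by MTT assay, with a stated time of 68 h (a higher number here means a weaker inhibitor, a lower number a stronger inhibitor), compound 1 gives 26200 nM. Compound 2 carries a thiophen-3-yl in place of the fluorophenyl ring, and in this assay it reaches only > 50000 nM, which is a limit of the assay and not a number, as noted in the limit of > 50000 nM in this assay, at which 1 of the 2 values shown sits. So compound 2 stands at the weak end of what was measured, and how far beyond that limit it actually lies is unknown.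

Compound 3, `O=C(Nc1cccc(-c2ccoc2)c1)C(Cl)Cl`, is the next step. It differs from compound 2 in one place: furan-3-yl in place of thiophen-3-yl on an aromatic carbon. Both rings are five-membered aromatics with a single hetero atom, so the change is small in size.

For compound 3 the step of a number no higher from compound 2 to compound 3 (the limit leaves the size open) is expected to stay within the usual scatter of this assay. On that basis compound 3 is estimated at 50000 nM in this assay, with a range from 20000 nM to 150000 nM, and there is a fair chance that the assay again reports only a limit.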

Compound 3, half-maximal inhibitory concentration: > 50000 nM
Compound 3: no number, only a limit; the forecaster's own chance of this, stated with the estimate: 55%; the middle value sits exactly at the limit.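

No step can be read from compound 2 to compound 3, since both end at a limit of the assay and not at a number: the limit of > 50000 nM in this assay, at which 2 of the 3 values shown sit.

The compounds shown leave open how far past that limit compound 2 and compound 3 really lie in this assay, and so whether furan-3-yl in place of thiophen-3-yl makes any difference.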